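The source may report more compounds than this note shows. Statements on the series, on what has been measured and on what is new or still open speak of the compounds shown alone.

Measured so far in a functional assay on OVCAR-3 cells (Homo sapiens) for antiproliferative activity, read by WST assay, with a stated time of 72 h; on this read-out higher numbers stand for weaker inhibition and lower numbers for stronger inhibition:
Compound 1 `CCCCCCCCCCCCCCCCCC/N=c1\nc(N)c2ncn(Cc3ccccc3)c2c(N)n1` gives 4950 nM.
Compound 2 `CCCCCCCC/N=c1\nc(N)c2ncn(Cc3ccc(OC)cc3)c2c(N)n1` gives 3750 nM.

Both compounds share the same core and differ in the chain on the imine nitrogen and in the group on the ring nitrogen. In this assay compound 2 and compound 1 give numbers that lie within the usual scatter of each other, so neither can be placed ahead of the other on the evidence shown.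

Compound 3 `CCCCCCCC/N=c1\nc(N)c2nc[nH]c2c(N)n1` has not yet been measured. It differs from compound 2 by hydrogen in place of 4-methoxybenzyl on an aromatic nitrogen, with the chain on the imine nitrogen kept. Among the compounds with values here, no measured pair shows this change on its own, so its effect can only be estimated. A step toward weaker inhibition, somewhat beyond the scatter, is expected. Compound 3 is expected to give 9000 nM in this assay, with a range from 3000 nM to 30000 nM. The expected step of a 2.4-fold higher number from compound 2 to compound 3 (0.38 log units; beyond the scatter) therefore points toward weaker inhibition.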

Compound 3, half-maximal inhibitory concentration: "not active" (no number reported)
Compound 3 has no reported number here; there is nothing to compare the estimate with.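

In this assay, within the data shown here, compound 3 is reported as "not active" without a number, so no step from compound 2 to compound 3 can be read. Nothing shown bears on this result. The compounds shown leave open how much the 4-methoxybenzyl group contributes to inhibition.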